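The compounds below may be only part of what the source reports. "The series", "measured", "known", "first", "only" and "open" are said of these compounds alone.

The compounds described here share one core, and the measured members of the set are compound 1 `N#C/C(=C\c1c(-c2ccccc2)[nH]c2ccccc12)C(=O)c1ccccc1`, compound 2 `CCOC(=O)C(=Cc1c(-c2ccccc2)[nH]c2ccccc12)C(=O)OCC` and compound 3 `COc1ccc2[nH]c(-c3ccccc3)c(C=C(C#N)C#N)c2c1`. In a functional assay on PC-3 cells (Homo sapiens) for inhibition, read by sulforhodamine B assay, with a stated time of 48 h (on this read-out lower numbers stand for stronger inhibition of growth and higher numbers for weaker inhibition of growth), compound 1 gives 3500 nM. In the same assay compound 2 gives 3300 nM, and compound 3 gives 5400 nM. Neither of these two numbers separates from that of compound 1 beyond the usual scatter of repeated measurements, so the three compounds cannot be placed in any order on this read-out, and compound 1 stands simply among them.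

Compound 4 `N#C/C(=C\c1c(-c2ccccc2)[nH]c2ccccc12)S(=O)(=O)c1ccccc1` has not yet been measured. It differs from compound 1 in a single place: phenylsulfonyl in place of benzoyl on a double-bonded chain carbon bound to a double-bonded chain carbon and a triple-bonded carbon. For the measured compounds named here, no measured pair in this set shows the effect of such a change, so nothing from the data can be pointed to as a precedent. Given the flat picture across compounds 1, 2 and 3, the step from compound 1 to compound 4 in this assay is expected to be no change at the digits printed from compound 1 to compound 4 (within the scatter), that is, nothing beyond the scatter in either direction. Compound 4 is therefore estimated at 3500 nM, with a range from 1200 nM to 10000 nM.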

Compound 4, concentration for 50% growth inhibition: 3400 nM
For compound 4 the middle estimate is 1.0-fold (0.01 log units) above the measured one; the measured number falls inside the stated range.
By their numbers in this assay, from the lowest: compounds 2, 4, 1 and 3 (each within the scatter of the next).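

In this assay, for the compounds shown here, replacing benzoyl with phenylsulfonyl gives a 1.0-fold lower number from compound 1 to compound 4 (0.01 log units; within the scatter), and this is the first single-place step in the set. At this place, on a double-bonded chain carbon bound to a double-bonded chain carbon and a triple-bonded carbon, the read-out therefore does not separate the two groups, even though phenylsulfonyl brings in a sulfur atom that benzoyl lacks. No supporting measurement bears on why the two groups read alike.

The compounds shown leave open whether a carboxylic acid, an amine or a longer chain at this place would also stay within the scatter. They also leave open whether phenylsulfonyl and benzoyl would still read alike if a methoxy group were present on the shared core, as it is in compound 3.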